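The source may report more compounds than this note shows. Statements on the series, on what has been measured and on what is new or still open speak of the compounds shown alone.

Compound 2 `O=c1ncn(Cc2c(F)cc(F)cc2F)c2ccc(Oc3cccc(-c4nc5ncccc5o4)c3C(F)(F)F)cc12` gives 3 10^-6 cm/s in an ADME assay on Caco-2 cells (Homo sapiens) for permeability, in the apical to basolateral direction (on this read-out higher numbers stand for higher permeability and lower numbers for lower permeability), the lowest of the three numbers at hand. Compound 1 `O=c1ncn(Cc2c(F)cc(F)cc2F)c2ccc(Oc3ccccc3C(F)(F)F)cc12` gives 9.2 10^-6 cm/s, and compound 3 `Nc1ccc(-c2cccc(Oc3ccc4c(c3)c(=O)ncn4Cc3c(F)cc(F)cc3F)c2C(F)(F)F)cn1` gives 4.1 10^-6 cm/s. Compound 4 `Cc1cc(-c2cccc(Oc3ccc4c(c3)c(=O)ncn4Cc3c(F)cc(F)cc3F)c2C(F)(F)F)cnc1N` differs from compound 2 by a group of 8 heavy atoms (6 carbon, 2 nitrogen; one six-membered aromatic ring with 1 hetero atom) in place of a group of 9 heavy atoms (6 carbon, 2 nitrogen, 1 oxygen; one five-membered aromatic ring with 2 hetero atoms, one six-membered aromatic ring with 1 hetero atom), on an aromatic carbon. The most relevant measured step is a 1.4-fold higher number from compound 2 to compound 3 (0.14 log units; within the scatter), where the same group leaves and a group differing from the entering one only by a methyl arrives. The steps of a 3.1-fold lower number from compound 1 to compound 2 (0.49 log units; beyond the scatter) and a 2.2-fold lower number from compound 1 to compound 3 (0.35 log units; beyond the scatter) show that either large group gives a lower number than a hydrogen atom, without separating the two clearly. A step within the scatter is therefore expected: a 1.3-fold higher number from compound 2 to compound 4 (0.10 log units; within the scatter). Compound 4 is estimated at 3.8 10^-6 cm/s, with a range from 2 10^-6 cm/s to 7 10^-6 cm/s.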

Compound 4, apparent permeability: 1.1 10^-6 cm/s
Beside the measured number, compound 4's estimate is 3.5-fold (0.54 log units) above it, outside the stated range (below it).
By their numbers in this assay, from the lowest: compound 4; then compounds 2 and 3 (each within the scatter of the next); then compound 1.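

In this assay the smallest change of the series has the biggest effect among close analogues: one methyl gives a 3.7-fold lower number from compound 3 to compound 4 (0.57 log units; beyond the scatter) and so the group at this aromatic carbon matters in finer detail than compound 3 alone suggested. The new group also differs measurably from the fused bicyclic group, with a 2.7-fold lower number from compound 2 to compound 4 (0.44 log units; beyond the scatter) and, against the parent with hydrogen, an 8.4-fold lower number from compound 1 to compound 4 (0.92 log units; beyond the scatter) as the largest drop of the series. No measurement at hand explains the methyl effect. Going by these compounds, it remains open whether a chlorine atom or an ethyl group in place of this methyl would give a similar number.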